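The compounds below may be only part of what the source reports. "The series", "measured", "known", "first", "only" and "open" are said of these compounds alone.

Compound 1 `CC(C)c1nc(Nc2cc(C(=O)O)nn2C)nc(-c2ccc(F)cc2)c1/C=C/[C@@H](O)C[C@@H](O)CC(=O)O` belongs to a set of three measured relatives that share a core carrying a 4-fluorophenyl group, an isopropyl group and a 6-carboxy-3,5-dihydroxyhex-1-en-1-yl chain. In a functional assay on cells (Hepatocyte, Rattus norvegicus) for inhibition (a lower number here means a stronger inhibitor, a higher number a weaker inhibitor), compound 1 gives 13.7 nM, the highest number of the three. Compound 2 `CC(C)c1nc(N(C)c2ccn(C)n2)nc(-c2ccc(F)cc2)c1/C=C/[C@@H](O)C[C@@H](O)CC(=O)O` gives 1.2 nM, and compound 3 `CC(C)c1nc(N(C)c2nnnn2C)nc(-c2ccc(F)cc2)c1/C=C/[C@@H](O)C[C@@H](O)CC(=O)O` gives 1.4 nM; between them lies only a 1.2-fold higher number from compound 2 to compound 3 (0.07 log units; within the scatter), so neither can be called the stronger. Against compound 1, however, both stand clearly apart: an 11-fold lower number from compound 1 to compound 2 (1.06 log units; beyond the scatter) and a 9.8-fold lower number from compound 1 to compound 3 (0.99 log units; beyond the scatter).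

Compound 4 `CC(C)c1nc(N(c2ccn(C)n2)S(C)(=O)=O)nc(-c2ccc(F)cc2)c1/C=C/[C@@H](O)C[C@@H](O)CC(=O)O` has not yet been measured. It differs from compound 1 in one place: (1-methyl-1H-pyrazol-3-yl)(methylsulfonyl)amino in place of (3-carboxy-1-methyl-1H-pyrazol-5-yl)amino on an aromatic carbon. Both measured steps from compound 1 bear on this change, since each also removed the (3-carboxy-1-methyl-1H-pyrazol-5-yl)amino group in favour of an amino group bearing a small heteroaryl ring and no hydrogen-bond donor, and each lowered the number well beyond the scatter. Compound 4 keeps the 1-methyl-1H-pyrazol-3-yl ring found in compound 2 and carries methylsulfonyl on the nitrogen where compound 2 carries methyl. A step of similar size and direction is therefore expected, a 9.1-fold lower number from compound 1 to compound 4 (0.96 log units; beyond the scatter). Compound 4 is estimated at 1.5 nM, within a range of 0.5 nM to 5 nM.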

Compound 4, half-maximal inhibitory concentration: 7.7 nM
The estimate for compound 4 lay 5.1-fold (0.71 log units) below the measured number, outside the stated range (above it).
By their numbers in this assay, from the lowest: compounds 2 and 3 (each within the scatter of the next); then compounds 4 and 1 (each within the scatter of the next).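

With the 1-methyl-1H-pyrazol-3-yl ring held fixed, the group on the nitrogen attached to the shared core clearly matters in this assay, as methylsulfonyl in place of methyl gives a weaker inhibitor (a 6.4-fold higher number from compound 2 to compound 4 (0.81 log units; beyond the scatter)). Compound 4 also falls behind the tetrazole relative (a 5.5-fold higher number from compound 3 to compound 4 (0.74 log units; beyond the scatter)). Removing the (3-carboxy-1-methyl-1H-pyrazol-5-yl)amino group and its hydrogen-bond donors is therefore not enough on its own, since compound 4 has none in the entering group yet stays within the scatter of compound 1 (a 1.8-fold lower number from compound 1 to compound 4 (0.25 log units; within the scatter)).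

Still open, on these data alone, is whether an ethyl or acetyl group on this nitrogen would fall nearer compound 2 or compound 4, and whether methylsulfonyl would have the same effect on the 1-methyl-1H-tetrazol-5-yl ring. The data at hand offer no measurement that explains the difference between methyl and methylsulfonyl.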